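The source may report more compounds than this note shows. Statements on the series, on what has been measured and on what is new or still open speak of the compounds shown alone.

Three compounds share one core and differ only in the group on an amine nitrogen in a ring. Compound 1 `CC(C)N1CCN(Cc2csc(N)c2C(=O)c2ccc(Cl)cc2)CC1` carries isopropyl there, compound 2 `Nc1scc(CN2CCN(c3ccccc3F)CC2)c1C(=O)c1ccc(Cl)cc1` carries 2-fluorophenyl, and compound 3 `Nc1scc(CN2CCN(c3cccc(F)c3F)CC2)c1C(=O)c1ccc(Cl)cc1` carries 2,3-difluorophenyl. In an assay on CHO cells for displacement of a labelled ligand from adenosine receptor A1 (Homo sapiens), read by scintillation counting, with a stated time of 120 min, tested at 10 uM (on this read-out higher numbers stand for more inhibition at the one concentration tested (going by the name of the read-out) and lower numbers for less inhibition), compound 1 gives 0%, compound 2 gives 4% and compound 3 gives 0%. The steps between them are a number 4 percentage points higher from compound 1 to compound 2 (within the scatter), no change at the digits printed from compound 1 to compound 3 (within the scatter) and a number 4 percentage points lower from compound 2 to compound 3 (within the scatter), so compound 3 stands level with compound 1 in this assay and within the scatter of compound 2. Compound 4 `Nc1scc(CN2CCN(c3ccccc3Cl)CC2)c1C(=O)c1ccc(Cl)cc1` is not yet measured; it differs from compound 3 in that (2-chlorophenyl in place of 2,3-difluorophenyl on an amine nitrogen in a ring). Within the data shown here, the steps that bear on this change are a number 4 percentage points lower from compound 2 to compound 3 (within the scatter), which swapped fluoro in place of hydrogen on an aromatic carbon, together with no change at the digits printed from compound 1 to compound 3 (within the scatter) and a number 4 percentage points higher from compound 1 to compound 2 (within the scatter), which each put an aryl group in place of isopropyl on that nitrogen; none of them moved the number beyond the scatter. The step of a number 2 percentage points higher from compound 3 to compound 4 (within the scatter) is therefore expected to stay within the scatter. Compound 4 is estimated at 2%, with a range from 0% to 12%.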

Compound 4, a percentage reported as inhibition, at one concentration (the size of the read-out at that concentration, not a potency): 2%
The estimate for compound 4 equals the measured number at the digits printed; measured number inside the range.
By their numbers in this assay, from the lowest: compounds 1, 3, 4 and 2 (each within the scatter of the next).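

The first chlorine on this aryl group leaves the reading in this assay within the scatter: 2-chlorophenyl in place of 2,3-difluorophenyl gives a number 2 percentage points higher from compound 3 to compound 4 (within the scatter), and chloro in place of fluoro gives a number 2 percentage points lower from compound 2 to compound 4 (within the scatter). Against isopropyl on the same amine nitrogen, 2-chlorophenyl gives a number 2 percentage points higher from compound 1 to compound 4 (within the scatter), so neither the kind of halogen nor the aryl group separates these four compounds on this read-out. Nothing available here offers a reason for these numbers.

As far as these compounds go, it remains open whether a methoxy group on the phenyl ring, or a longer chain or carboxylic acid on that nitrogen, would move the number beyond the scatter. Also open, from the compounds shown here alone, is whether replacing the 4-chlorophenyl ketone part of the shared core would do so.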